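The compounds below may be only part of what the source reports. "The series", "measured", "known", "first", "only" and "open" are said of these compounds alone.

Measured compounds:
compound 1 `CCCSc1nc(N/N=C/c2ccccc2Cl)c2nnn(Cc3ccccc3)c2n1`, 6180 nM
compound 2 `C#CCSc1nc(N/N=C(\C)c2ccccc2O)c2nnn(Cc3ccccc3)c2n1`, 5250 nM
compound 3 `CCCSc1nc(N/N=C(\C)c2ccccc2O)c2nnn(Cc3ccc(F)cc3)c2n1`, 21900 nM

These three compounds were tested in a functional assay on ECa-109 cells (Homo sapiens) for antiproliferative activity, read by MTT assay, with a stated time of 72 h; a lower number here means a stronger inhibitor, a higher number a weaker inhibitor. Compound 1 gives 6180 nM, which is the second highest of the three numbers. Compound 2 gives 5250 nM, and this number and that of compound 1 lie within the scatter of each other, so nothing separates them. Compound 3 gives 21900 nM, a number further from compound 1 and beyond the scatter, so compound 1 shows the lower number of that pair.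

Compound 4 `CCCSc1nc(N/N=C/c2ccc(Br)cc2)c2nnn(Cc3ccccc3)c2n1` has not been measured in this assay. It is built from compound 1 by one change: 4-bromophenyl in place of 2-chlorophenyl on a carbon with a double bond to nitrogen. Among the compounds with values here, no measured pair shows this kind of change, so there is no step to lean on. The expectation is therefore a step of a 1.1-fold higher number from compound 1 to compound 4 (0.02 log units; within the scatter), that is, none beyond the scatter in either direction. Compound 4 is estimated at 6500 nM, with a range from 2500 nM to 16000 nM.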

Compound 4, half-maximal inhibitory concentration: > 64000 nM
Compound 4: no number, only a limit (the forecaster's own chance of this, stated with the estimate: 5%); middle value at least 9.8-fold (0.99 log units) from the limit.
By their numbers in this assay, from the lowest: compounds 2 and 1 (each within the scatter of the next); then compound 3. At a limit, above all of these: compound 4.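

In this assay compound 4 gives > 64000 nM, which is a limit of the assay and not a number. Placing 4-bromophenyl in place of 2-chlorophenyl on a carbon with a double bond to nitrogen gives an at least 10-fold higher number from compound 1 to compound 4 (1.01 log units; beyond the scatter), so this position is far from indifferent to which halogen-bearing phenyl it carries, even though the two groups match in heavy-atom count, ring and hydrogen-bond donors and acceptors. This is the only step in one place among the compounds shown, and its full size stays unknown: the limit of > 64000 nM in this assay, at which 1 of the 4 values shown sits.

The halogen and its place on the ring changed together, so the compounds shown leave open which of the two matters; 4-chlorophenyl or 2-bromophenyl would separate them. From the compounds shown here alone, how an amine or a carboxylic acid on this phenyl ring would read also remains open.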